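A few compounds are considered here, and "the series" means these few. Any claim that something is new, unique, unknown or untested is made for them only; others in the source may bear on it.

Measured compounds:
Compound 1 `O=C1C=C(N2CCC2)C(=O)c2c1nc1n2[C@H]2OC[C@@H](O)[C@H]2OC1` gives in a functional assay on MCF7 cells (Homo sapiens) for inhibition, read by sulforhodamine B assay (a lower number here means a stronger inhibitor, a higher number a weaker inhibitor), a value of > 16000 nM, which is a limit of the assay rather than a number.
Compound 2 `Cc1ccc(NC2=CC(=O)c3c(nc4n3[C@H]3OC[C@@H](O)[C@H]3OC4)C2=O)cc1C` gives in this assay a value of 4950 nM.
Compound 3 `CCc1ccc(NC2=CC(=O)c3nc4n(c3C2=O)[C@H]2OC[C@@H](O)[C@H]2OC4)cc1` gives in this assay a value of 960 nM.

Among the two numbers available, compound 2 stands highest; its nearest neighbour is compound 3, whose number is lower by a margin beyond the scatter. Compound 1 sits at the limit (the limit of > 16000 nM in this assay, at which 1 of the 3 values shown sits), so it gives no number to compare.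

The unmeasured compound 4 `O=C1C(Nc2cccc(Cl)c2)=CC(=O)c2c1nc1n2[C@H]2OC[C@@H](O)[C@H]2OC1` differs from compound 2 only on the amine nitrogen: 3-chlorophenyl in place of 3,4-dimethylphenyl on an amine nitrogen.

For the measured compounds named here, only one measured step is available, an at least 16-fold lower number from compound 1 to compound 3 (1.22 log units; beyond the scatter), and it concerns a different change, the replacement of azetidin-1-yl by an arylamino group, not a change of substitution within an arylamino group. Going by the values given here, the values of compound 2 and compound 3 show that the substitution pattern of the aryl group can move the number by more than the scatter, but no measured pair tells which way a 3-chlorophenyl will go. A step of modest size in this assay, with uncertain direction, is therefore expected: a 1.7-fold lower number from compound 2 to compound 4 (0.22 log units; within the scatter). Compound 4 is estimated at 3000 nM, with a range from 800 nM to 12000 nM.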

Compound 4, half-maximal inhibitory concentration: 2970 nM
Beside the measured number, compound 4's estimate is 1.0-fold (0.00 log units) above it; measured number inside the range.
By their numbers in this assay, from the lowest: compound 3; then compounds 4 and 2 (each within the scatter of the next). At a limit, above all of these: compound 1.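

In this assay, 3-chlorophenyl in place of 3,4-dimethylphenyl on the amine nitrogen gives a 1.7-fold lower number from compound 2 to compound 4 (0.22 log units; within the scatter), so this change does not move the number measurably. For the compounds shown here, it is the only measured step that stays within an arylamino group, and it shows that one chlorine can replace the two methyl groups here with no difference that stands out from the scatter. Nothing in the data shown accounts for this step.

Going by these compounds, whether a methoxy group or a carboxylic acid on the phenyl ring would move the number beyond the scatter remains open. So does the effect of a benzyl group or a longer alkyl chain in place of the phenyl ring on the amine nitrogen.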